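The source may hold more compounds than are shown below. What is called first, only, known or untested is meant among the compounds shown, and "the series" means these compounds.

Measured so far:
compound 1, `Cc1cc(O)c(C(C)C)cc1-c1cc(-c2ccccc2)c(C#N)c(=O)[nH]1`: 58%
compound 2, `Cc1cc(O)c(C(C)C)cc1-c1cc(-c2ccccc2[N+](=O)[O-])c(C#N)c(=O)[nH]1`: 35%

In a functional assay for inhibition, tested at 80 ug/mL (a lower number here means a weaker effect, a higher number a stronger effect of the compound at the concentration tested), compound 1 gives 58%, and compound 2 gives 35%. Going by the values given here, of the two numbers, compound 2 stands lowest; its nearest neighbour is compound 1, and the single measured step, nitro in place of hydrogen on an aromatic carbon, reads a number 23 percentage points lower from compound 1 to compound 2 (beyond the scatter). Compound 3, `Cc1cc(O)c(C(C)C)cc1-c1cc(-c2ccccc2Cl)c(C#N)c(=O)[nH]1`, has not yet been measured in this assay. It differs from compound 2 in one place: chloro in place of nitro on an aromatic carbon. Among the compounds with values here, the only step that bears on this change is the one from compound 1 to compound 2, which put the nitro group in place at a modest cost; compound 3 takes that group away again and sets chloro where it stood. Whether chloro will behave more like the hydrogen of compound 1 or like the nitro of compound 2 cannot be told from two numbers. A step upward is expected, smaller than the earlier step downward, namely a number 12 percentage points higher from compound 2 to compound 3 (beyond the scatter). Compound 3 is therefore estimated at 47%, with a range from 32% to 62%.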

Compound 3, a percentage reported as inhibition, at one concentration (the size of the read-out at that concentration, not a potency): 32%
The estimate for compound 3 lay 15 percentage points above the measured number; the range from low to high includes it.
By their numbers in this assay, from the lowest: compounds 3 and 2 (each within the scatter of the next); then compound 1.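

In this assay, the change from 2-nitrophenyl to 2-chlorophenyl reads a number 3 percentage points lower from compound 2 to compound 3 (within the scatter), so this pair does not separate the two groups, although nitro brings three heavy atoms and two hydrogen-bond acceptors and chloro brings one heavy atom and no acceptor. Chloro in place of hydrogen on the same aromatic carbon, ortho to a large group, reads a number 26 percentage points lower from compound 1 to compound 3 (beyond the scatter), which stands alongside a number 23 percentage points lower from compound 1 to compound 2 (beyond the scatter) and shows that the lower number seen with the nitro compound is not confined to nitro: among the three compounds, both groups at this place give lower numbers than hydrogen, and none goes against this. Nothing measured here accounts for the two groups reading alike.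

The compounds shown leave open whether a methyl, a methoxy group, an amine or a fluoro group at this place would also give a number near those of compound 2 and compound 3, or one nearer that of compound 1. They also leave open whether chloro or nitro on another carbon of the same aromatic ring would read the same way.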